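The source may report more compounds than this note shows. Statements on the series, on what has been measured and on what is new or still open speak of the compounds shown alone.

Compound 3 `O=C(Nc1cccc(/C=C/C(=O)c2nc3ccccc3[nH]2)c1)c1cc(Cl)cc(Cl)c1` gives 3660 nM in a functional assay on 143B cells (Homo sapiens) for antiproliferative activity, read by MTT assay, with a stated time of 48 h; a higher number here means a weaker inhibitor, a lower number a stronger inhibitor. Compound 2 `Cc1cccc(C(=O)Nc2cccc(/C=C/C(=O)c3nc4ccccc4[nH]3)c2)c1` gives 4880 nM, which sits within the scatter of compound 3, while compound 1 `O=C(Nc1cccc(/C=C/C(=O)c2nc3ccccc3[nH]2)c1)c1ccc(Cl)cc1` gives 7440 nM, separated from compound 3 by a step beyond the scatter: a 2.0-fold lower number from compound 1 to compound 3 (0.31 log units; beyond the scatter). The other steps, a 1.5-fold lower number from compound 1 to compound 2 (0.18 log units; within the scatter) and a 1.3-fold lower number from compound 2 to compound 3 (0.12 log units; within the scatter), stay within the scatter. Compound 4 `Cc1ccc(S(=O)(=O)Nc2cccc(/C=C/C(=O)c3nc4ccccc4[nH]3)c2)cc1` differs from compound 3 by (4-methylphenyl)sulfonyl in place of (3,5-dichlorophenyl)carbonyl on a nitrogen on an aromatic ring. Among the measured compounds shown here, none of the measured steps exchanges the carbonyl for a sulfonyl; they vary only the aryl group on the carbonyl, and those exchanges moved the number little. The step of a 1.4-fold higher number from compound 3 to compound 4 (0.14 log units; within the scatter) is therefore expected to be small, in no particular direction. Compound 4 is estimated at 5000 nM, with a range of 1800 nM to 14000 nM.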

Compound 4, half-maximal inhibitory concentration: 3220 nM
For compound 4 the middle estimate is 1.6-fold (0.19 log units) above the measured one; measured number inside the range.
By their numbers in this assay, from the lowest: compounds 4, 3, 2 and 1 (each within the scatter of the next, the first and the last beyond it).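

In this assay, the nitrogen on an aromatic ring carries a sulfonyl as readily as a carbonyl, which the aryl changes on the carbonyl could not show: a 1.1-fold lower number from compound 3 to compound 4 (0.06 log units; within the scatter) and a 1.5-fold lower number from compound 2 to compound 4 (0.18 log units; within the scatter) both stay within the scatter. Only a 2.3-fold lower number from compound 1 to compound 4 (0.36 log units; beyond the scatter) goes beyond it, so compound 4 matches the two better carbonyl compounds rather than compound 1. Nothing available explains this result. Since the aryl group changes along with the linking group in each step, their contributions remain unseparated. Also open, on these data alone, is how an amine or a carboxylic acid on that aryl ring would read.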